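A few compounds are considered here, and "the series" means these few. Any claim that something is new, unique, unknown or untested is made for them only; others in the source may bear on it.

Measured compounds:
- compound 1, `O=C(CCCCC1CCSS1)Nc1ccccn1`: 37.6%
- compound 2, `O=C(CCCCC1CCSS1)Nc1ccc(Cl)cn1`: 48.5%
- compound 3, `O=C(CCCCC(S)CCS)Nc1ccccc1`: 7.67%

In a functional assay on Bel-7402 cells (Homo sapiens) for inhibition, read by MTT assay, with a stated time of 24 h, tested at 100 ug/mL (a higher number here means more inhibition of growth at the concentration tested, a lower number less inhibition of growth), compound 1 gives 37.6% and compound 2 gives 48.5%. For the measured compounds named here, the one change between them is chloro in place of hydrogen on an aromatic carbon; the step is a number 10.9 percentage points higher from compound 1 to compound 2 (beyond the scatter). Compound 3 stands lowest of the three in this assay with 7.67%; the difference between its core and the core of compound 1 is not broken down here.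

Compound 4, `O=C(CCCCC(S)CCS)Nc1cccc(Cl)c1`, is not yet measured. It differs from compound 3 by chloro in place of hydrogen on an aromatic carbon. This is the same kind of change as that from compound 1 to compound 2, but not the same: there the chloro sits on a six-membered aromatic ring with 1 nitrogen, two atoms from the ring nitrogen, para to a large group, whereas here it sits on a six-membered aromatic ring of carbon only, meta to a large group.

Going by the values given here, for compound 4 in this assay a step of about a number 8.3 percentage points higher from compound 3 to compound 4 (within the scatter) is expected, resting on the single precedent a number 10.9 percentage points higher from compound 1 to compound 2 (beyond the scatter). The starting point is low: compound 3 gives 7.67% in this assay. The estimate for compound 4 is 16%, within 4% to 30%.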

Compound 4, percent growth inhibition at one concentration: 16.1%
Estimate against measurement, compound 4: 0.1 percentage points below, and the stated range covers the measured number.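

In this assay, chloro in place of hydrogen on an aromatic carbon gives a number 8.4 percentage points higher from compound 3 to compound 4 (within the scatter), so on the core of compound 3 this step alone cannot be told apart from repeat variation. Set beside the step on the core of compound 1, the size of the change carries over without a detectable difference: the same change on two cores in this assay, a number 10.9 percentage points higher (beyond the scatter) from compound 1 to compound 2 and a number 8.4 percentage points higher (within the scatter) from compound 3 to compound 4, 2.5 percentage points apart, within the scatter of two such steps

For the compounds shown here, this rests on only two pairs, and the chloro stands on a six-membered aromatic ring with 1 nitrogen in one pair and on a ring of carbon only in the other, so agreement between the steps does not show that the change transfers independently of ring, placement or core.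

Still open, going by these compounds, is whether a different group on the aromatic ring, such as methoxy, trifluoromethyl or an amine, would carry across these two cores in the same way. Also open, on these data alone, is how the chloro step would behave with a longer chain between the amide carbonyl and the sulfur-bearing end.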